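From methyl to cyclopentyl on a weak compound

A few compounds are considered here, and "the series" means these few. Any claim that something is new, unique, unknown or untested is made for them only; others in the source may bear on it.

Compound 1 `Fc1ccccc1Cn1nc(-c2ccco2)c2cccnc21` gives 9300 nM in a functional assay (aorta) with Oryctolagus cuniculus as the target (on this read-out lower numbers stand for stronger inhibition and higher numbers for weaker inhibition), and compound 2 `Fc1ccccc1Cn1nc(-c2ncccn2)c2cccnc21` gives 1250 nM. Compound 3 `Cc1cnc(-c2nn(Cc3ccccc3F)c3ncccc23)nc1N` gives 675000 nM, the highest number of the three, since the steps of a 73-fold higher number from compound 1 to compound 3 (1.86 log units; beyond the scatter) and a 540-fold higher number from compound 2 to compound 3 (2.73 log units; beyond the scatter) both lie beyond the scatter. Compound 4 `Nc1nc(-c2nn(Cc3ccccc3F)c3ncccc23)ncc1C1CCCC1` differs from compound 3 in one place: cyclopentyl in place of methyl on an aromatic carbon. Within the data shown here, no measured step exchanges one group for another at that place, so the comparisons in hand bear on it only indirectly, and none of them speaks for a change in either direction. Compound 4 is therefore expected to give a step of a 1.4-fold lower number from compound 3 to compound 4 (0.13 log units; within the scatter) that is not beyond the scatter. The estimate for compound 4 is 500000 nM, with a range from 100000 nM to 2000000 nM.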

Compound 4, half-maximal inhibitory concentration: 904000 nM
Beside the measured number, compound 4's estimate is 1.8-fold (0.26 log units) below it; the measured number falls inside the stated range.
By their numbers in this assay, from the lowest: compound 2; then compound 1; then compounds 3 and 4 (each within the scatter of the next).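

In this assay, cyclopentyl in place of methyl on this aromatic carbon, ortho to an amino group, gives a 1.3-fold higher number from compound 3 to compound 4 (0.13 log units; within the scatter). A group of 5 heavy atoms with a five-membered non-aromatic ring is thus tolerated here as well as a group of 1 heavy atom, with both compounds remaining on the weak side of the series. No measured evidence accounts for this result.

The compounds shown leave open whether an amine or a carboxylic acid at this place would move the number beyond the scatter. They also leave open whether a longer chain would do so.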